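The source may report more compounds than this note shows. Statements on the series, on what has been measured and on what is new or still open speak of the compounds shown alone.

For the measured compounds named here, compound 2 `CN(C)CCCCCSC1=Nc2ccccc2C(CC(=O)NCc2ccccc2)N1c1ccc(-c2ccccc2)cc1` gives 85.6% in an assay on cells for inhibition of Voltage-dependent T-type calcium channel subunit alpha-1I (Homo sapiens), read by patch clamp, tested at 10 uM (a higher number here means more inhibition at the concentration tested (going by the name of the read-out), a lower number less inhibition), the highest of the three numbers so far. Compound 1 `CN(C)CCCCCSC1=Nc2ccccc2C(CC(=O)NCc2ccccc2)N1c1ccc(-c2ccc(F)cc2)cc1` gives 66.7% and compound 3 `CN(C)CCCCCSC1=Nc2ccccc2C(CC(=O)NCc2ccc(F)cc2)N1c1ccc(-c2ccccc2)cc1` gives 69.3% in this assay, with a number 18.9 percentage points higher from compound 1 to compound 2 (beyond the scatter) and a number 16.3 percentage points lower from compound 2 to compound 3 (beyond the scatter). Both steps concern a fluoro on an aromatic carbon and neither touches the amine end of the chain, so neither bears on the next step. Compound 4 `O=C(CC1c2ccccc2N=C(SCCCCCN2CCCC2)N1c1ccc(-c2ccccc2)cc1)NCc1ccccc1` differs from compound 2 by pyrrolidin-1-yl in place of dimethylamino on a saturated chain carbon, five bonds along the chain from a sulfur. Going by the values given here, with no measured step at that position, the expectation is a step of a number 5.6 percentage points lower from compound 2 to compound 4 (within the scatter), within the scatter. Compound 4 is therefore estimated at 80% in this assay, between 60% and 95%.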

Compound 4, a percentage reported as inhibition, at one concentration (the size of the read-out at that concentration, not a potency): 92.7%
Compound 4: the middle estimate sits 12.7 percentage points below what was measured; measured number inside the range.
By their numbers in this assay, from the lowest: compounds 1 and 3 (each within the scatter of the next); then compounds 2 and 4 (each within the scatter of the next).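

Pyrrolidin-1-yl in place of dimethylamino on a saturated chain carbon, five bonds along the chain from a sulfur, gives a number 7.1 percentage points higher from compound 2 to compound 4 (within the scatter) in this assay so this position accepts a five-membered non-aromatic ring with no change beyond the scatter. The earlier steps shown here spoke only to fluoro on an aromatic carbon and lay beyond the scatter, whereas this amine-end change does not. No measured data bear on this result.

Still open, going by these compounds, is whether a piperidin-1-yl or morpholin-4-yl group at this place would hold the inhibition. On these data alone, a shorter chain between the sulfur and the amine is equally open.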